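Changing the Group on the Sulfur of Compound 2

The source may report more compounds than this note shows. Statements on the series, on what has been measured and on what is new or still open speak of the compounds shown alone.

Of the compounds shown here, two with the same long chains have been measured so far, and they differ only in the group on the sulfur. In a physicochemical assay for lipophilicity (on this read-out lower numbers stand for lower lipophilicity and higher numbers for higher lipophilicity), compound 1 (`CCCCCCN(CCCCCSc1nc2c([nH]1)CCCC2)C(=O)Nc1ccc(F)cc1F`) gives 6.81. Compound 2 (`CCCCCCN(CCCCCSc1nc2cc(C)ccc2[nH]1)C(=O)Nc1ccc(F)cc1F`) gives 7.79, the higher of the two numbers.

The next compound, compound 3 (`CCCCCCN(CCCCCSc1nc2ccc[nH]c-2n1)C(=O)Nc1ccc(F)cc1F`), changes that same group once more: a group of 9 heavy atoms (6 carbon, 3 nitrogen; one five-membered aromatic ring with 2 hetero atoms, one six-membered aromatic ring with 1 hetero atom) in place of a group of 10 heavy atoms (8 carbon, 2 nitrogen; one five-membered aromatic ring with 2 hetero atoms, one six-membered aromatic ring of carbon only), on a sulfur. The entering group has a hetero atom in its six-membered aromatic ring, whereas the ring it replaces is carbon only.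

For the measured compounds named here, only one measured step bears on this change, and it sits at the same sulfur: a number 0.98 log units higher from compound 1 to compound 2 (beyond the scatter). Going by the values given here, it shows that a swap at this place can move the number well beyond the scatter, though one step is thin evidence and no measured compound yet has a hetero atom in that six-membered ring. A fall of similar size seems the reasonable expectation, so the expected change is a number 1.29 log units lower from compound 2 to compound 3 (beyond the scatter). Compound 3 is estimated at 6.5, within an expected range from 5.9 to 7.1.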

Compound 3, partition coefficient: 6.22
Compound 3: the middle estimate sits 0.28 log units above what was measured, within the range that was stated.
By their numbers in this assay, from the lowest: compound 3; then compound 1; then compound 2.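

Placing a nitrogen in the six-membered aromatic ring gives the lowest number of the three compounds in this assay, with a number 1.57 log units lower from compound 2 to compound 3 (beyond the scatter) as the largest step seen so far at this sulfur. The new group also falls short of the non-aromatic ring of compound 1, shown by a number 0.59 log units lower from compound 1 to compound 3 (beyond the scatter) and placing the two compounds with aromatic six-membered rings on either side of compound 1, so having an aromatic ring there does not by itself set the number: what the ring carries matters as well. Nothing at hand accounts for the size or direction of these steps.

The step to compound 3 changes two things at once, since the methyl of the 5-methyl-1H-benzimidazol-2-yl group leaves as a ring carbon gives way to nitrogen, and the compounds shown cannot divide the fall between those two changes. The plain 1H-benzimidazol-2-yl group, without the methyl, would separate them, while a methyl added to the new group or a different ring nitrogen arrangement remains an open question at this sulfur.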